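The compounds below may be only part of what the source reports. "The series", "measured", "known", "first", "only" and "open" are said of these compounds alone.

Compound 1 `O=C(Nc1ccc(-n2ccc3c(NC(=O)c4ccccc4)ncnc32)cc1)Nc1ccc(Cl)c(C(F)(F)F)c1` is the anchor of this small set. In an ADME assay on HS27 cells (Homo sapiens) for antiproliferative activity, read by MTT assay, with a stated time of 24 h (a higher number here means a weaker inhibitor, a lower number a stronger inhibitor), compound 1 gives 6000 nM. Going by the values given here, that is the only actual number among the three measured compounds; the other two sit at the limit of > 10000 nM in this assay, at which 2 of the 3 values shown sit, so compound 1 stands alone with a measured figure.

Compound 2 `Nc1ncnc2c1ccn2-c1ccc(NC(=O)Nc2ccc(Cl)c(C(F)(F)F)c2)cc1` carries a hydrogen in place of the benzoyl group on the nitrogen of the shared core. In this assay compound 2 reaches only a limit, > 10000 nM. The step of an at least 1.6-fold higher number from compound 1 to compound 2 (0.22 log units; that floor lies within the scatter) shows how far that limit lies from the number for compound 1.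

Compound 3 `O=C(Nc1ccc(-n2ccc3c(NC(=O)c4ccccc4)ncnc32)cc1)Nc1cc(C(F)(F)F)cc(C(F)(F)F)c1` keeps the benzoyl group but changes the aryl group on the urea. In this assay compound 3 also reports a limit, > 10000 nM.

Compound 4 `O=C(Nc1ccc(-n2ccc3c(NC(=O)c4ccccc4)ncnc32)cc1)Nc1cccc(Cl)c1Cl` changes the same urea end, with 2,3-dichlorophenyl in place of 4-chloro-3-(trifluoromethyl)phenyl on an amide-type nitrogen. Among the compounds with values here, no measured step covers this exact change; the only measured step, from compound 1 to compound 2, concerns the other end of the molecule. What compound 3 shows is that a different aryl swap at this end gave a limit where compound 1 gave a number. Compound 4 is therefore expected to give a step of a 1.3-fold higher number from compound 1 to compound 4 (0.12 log units; within the scatter). Compound 4 is estimated at 8000 nM, between 3000 nM and 20000 nM.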

Compound 4, half-maximal inhibitory concentration: 7800 nM
Compound 4: the middle estimate sits 1.0-fold (0.01 log units) above what was measured, within the range that was stated.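

In this assay, the far end of the urea can carry 2,3-dichlorophenyl in place of 4-chloro-3-(trifluoromethyl)phenyl and still return a real number, and the step is a 1.3-fold higher number from compound 1 to compound 4 (0.11 log units; within the scatter), so this swap cannot be told apart from no change at all. Compound 3, with a different aryl group on the same amide-type nitrogen, stands at a limit of the assay, > 10000 nM, and so gives no number to compare. Compound 4 therefore adds what compound 3 could not: a measured case of an aryl swap at this place, showing that a change of aryl group here does not always end at the limit.

Much of the set still consists of limits rather than numbers, which leaves only a narrow view of how far any change can move the result: the limit of > 10000 nM in this assay, at which 2 of the 4 values shown sit. Still open, as far as these compounds go, is how this end of the molecule would read with a plain phenyl ring, or with a methoxy group or a carboxylic acid on that ring, and whether any such group would give a number clearly beyond the scatter from compound 1.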